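Urea terminus change on the shared core: compound 4

The source may hold more compounds than are shown below. What is called first, only, known or untested is meant among the compounds shown, and "the series" means these compounds.

Compound 3 `CCOc1ccc(NC(=O)Nc2cccc(CNc3nccnc3Cl)c2)cc1` is followed here to compound 4 `O=C(Nc1cccc(CNc2nccnc2Cl)c1)NC1CCCCC1`. In a functional assay on HepG2 cells (Homo sapiens) for antiproliferative activity, read by MTT assay, with a stated time of 48 h (a higher number here means a weaker inhibitor, a lower number a stronger inhibitor), compound 3 gives 7050 nM, the lowest of the two numbers available; compound 2 `O=C(Nc1cccc(CNc2nccnc2Cl)c1)Nc1ccccc1Cl` is nearest at 8560 nM, and the gap is within the scatter. In this assay compound 1 `O=C(Nc1cccc(CNc2nccnc2Cl)c1)Nc1cccc2ccccc12` gives > 40000 nM, which is a limit of the assay and not a number.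

The change to compound 4 is cyclohexyl in place of 4-ethoxyphenyl on an amide-type nitrogen. Among the measured compounds shown here, the only measured step on this nitrogen is a 1.2-fold lower number from compound 2 to compound 3 (0.08 log units; within the scatter), which exchanges one aromatic ring for another; no measured step replaces an aromatic ring with a non-aromatic one, so the measured data speak to this change only indirectly. Given that the one step on this position is within the scatter, no step beyond the scatter is expected, but the range is kept wide because the change is of a different kind.

The step from compound 3 to compound 4 is expected to be a 1.3-fold higher number from compound 3 to compound 4 (0.11 log units; within the scatter). Compound 4 is therefore estimated at 9000 nM in this assay, within 3000 nM to 30000 nM.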

Compound 4, half-maximal inhibitory concentration: > 40000 nM
Compound 4: only a limit was reported (the forecaster's own chance of this, stated with the estimate: 15%); middle value at least 4.4-fold (0.64 log units) from the limit.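

In this assay, this amide-type nitrogen proves sensitive to the kind of ring it carries: cyclohexyl gives an at least 5.6-fold higher number from compound 3 to compound 4 (0.75 log units; beyond the scatter) and an at least 4.6-fold higher number from compound 2 to compound 4 (0.66 log units; beyond the scatter), whereas the exchange of one aromatic ring for another gave only a 1.2-fold lower number from compound 2 to compound 3 (0.08 log units; within the scatter). An aromatic ring is not enough on its own to keep a measurable number, since compound 1, which also carries one, gives > 40000 nM, a limit and not a number. Both new steps rest on a limit for compound 4, so they set only a minimum size: the limit of > 40000 nM in this assay, at which 2 of the 4 values shown sit.

Going by these compounds, it remains open whether the loss belongs to cyclohexyl alone or extends to other non-aromatic groups, such as a linear hexyl chain. Also open, on these data alone, is whether an amine or a carboxylic acid on the cyclohexyl ring would bring the number back within range.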